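The source may hold more compounds than are shown below. What is called first, only, known or untested is meant among the compounds shown, and "the series" means these compounds.

Measured compounds:
compound 1 `CCO[C@H](c1ccc(O[C@@H](CO)[C@@H](O)c2ccc(O)c(OC)c2)c(OC)c1)[C@H](CO)c1ccc(O)c(OC)c1`, a functional assay, with a stated time of 30 min; a higher number here means a weaker inhibitor, a lower number a stronger inhibitor: 56800 nM
compound 2 `CCO[C@H](c1ccc(O[C@@H](CO)[C@@H](OC)c2ccc(O)c(OC)c2)c(OC)c1)[C@H](CO)c1ccc(O)c(OC)c1`, this assay: 81600 nM

Among the measured compounds shown here, compound 1 holds the lower of the two numbers, but the only measured step, a 1.4-fold higher number from compound 1 to compound 2 (0.16 log units; within the scatter), is within the scatter, so the two values do not separate.

Compound 3 `CCO[C@H](c1ccc(O[C@@H](CO)[C@@H](O)c2ccc(O)c(OC)c2)c(OC)c1)[C@@H](CO)c1ccc(O)c(OC)c1` differs from compound 1 in this way: the two compounds have the same atoms and bonds and differ only in configuration as drawn: 1 of 4 stereo elements differ; a stereocentre at a saturated chain carbon is drawn S in compound 1 and R in compound 3. For the measured compounds named here, no measured step concerns a change of configuration. Going by the values given here, the single step on hand, methyl in place of hydrogen on an oxygen on a saturated carbon, leaves the number essentially unchanged and says nothing about a stereocentre. The expectation for compound 3 in this assay therefore rests on the value of compound 1 alone, with a wide range given the lack of precedent; the expected step is a 1.1-fold higher number from compound 1 to compound 3 (0.02 log units; within the scatter), none beyond the scatter in either direction. Compound 3 is estimated to give 60000 nM, with a range from 20000 nM to 180000 nM.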

Compound 3, half-maximal inhibitory concentration: 79600 nM
Beside the measured number, compound 3's estimate is 1.3-fold (0.12 log units) below it; the measured number falls inside the stated range.
By their numbers in this assay, from the lowest: compounds 1, 3 and 2 (each within the scatter of the next).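

Changing the stereocentre at a saturated chain carbon from S to R gives a 1.4-fold higher number from compound 1 to compound 3 (0.15 log units; within the scatter) in this assay. Among the compounds shown here, this is the first measured change at this position, and earlier compounds spoke only to methyl in place of hydrogen on an oxygen on a saturated carbon; the inversion at this single centre does not separate the two compounds in this assay. The reading can be tied to this one stereocentre alone because nothing else in the structure changes: the fact that compounds 1 and 3 differ only in the configuration as drawn.

From the compounds shown here alone, the other stereo elements of the shared core remain open, since they are drawn alike in the compounds compared here. Also open, going by these compounds, is how this assay would respond to a different group on the core of compound 1, such as an amine or a carboxylic acid.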